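A few compounds are considered here, and "the series" means these few. Any claim that something is new, unique, unknown or untested is made for them only; others in the source may bear on it.

Measured in a functional assay on AGS cells (Homo sapiens) for antiproliferative activity, read by MTT assay, with a stated time of 48 h; on this read-out lower numbers stand for stronger inhibition of growth and higher numbers for weaker inhibition of growth:
- compound 1 `COc1ccc(N(C)c2ncnc3[nH]cnc23)cc1`: > 100000 nM (a limit of the assay, not a number)
- compound 2 `COc1ccc(N(C)c2nc(Cl)nc3[nH]cnc23)cc1`: 30000 nM
- compound 3 `COc1ccc(N(C)c2nc(Cl)nc3c2ncn3C)cc1`: 260 nM

Compound 1 has no exact value on this scale, only a limit: the limit of > 100000 nM in this assay, at which 1 of the 3 values shown sits. Compound 4 `COc1ccc(Cn2cnc3c(N(C)c4ccc(OC)cc4)ncnc32)cc1` has not yet been measured. It keeps the core of compound 1 but carries 4-methoxybenzyl in place of hydrogen on an aromatic nitrogen.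

Going by the values given here, the closest precedent is a change at an aromatic nitrogen, where methyl replaces hydrogen: a 120-fold lower number from compound 2 to compound 3 (2.06 log units; beyond the scatter). That large step points towards a lower number in this assay. It is only a partial guide, as compound 2 and compound 3 both carry chloro, which compound 4 lacks, and methyl is far smaller than 4-methoxybenzyl. The chloro step, an at least 3.3-fold lower number from compound 1 to compound 2 (0.52 log units; beyond the scatter), does not apply directly, since compound 4 gains no chloro. A clear but smaller gain than the methyl step is therefore expected, and the expected change is an at least 10-fold lower number from compound 1 to compound 4 (1.00 log units; beyond the scatter). For compound 4, the estimated value is 10000 nM, with an expected range of 1500 nM to 60000 nM.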

Compound 4, concentration for 50% growth inhibition: > 100000 nM
Compound 4 gave a limit, no number (the forecaster's own chance of this, stated with the estimate: 25%); middle value at least 10-fold (1.00 log units) away from the limit.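

Compound 1 and compound 4 both give a limit rather than a number, so no step between them can be read: the limit of > 100000 nM in this assay, at which 2 of the 4 values shown sit.

The compounds shown leave open whether 4-methoxybenzyl on this aromatic nitrogen changes growth inhibition at all, with or without chloro also present.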